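This account rests on a few compounds, and the source may have more. Where it says the series, first, only, none or still open, it means among the compounds named here.

Measured so far:
Compound 1, `CCCn1ccc2cc(-c3cncnc3)cc(Cl)c2c1=O`, gives 28% in a functional assay on CHO cells for agonist activity at metabotropic glutamate receptor 2 (Homo sapiens), read by GTPgammaS binding; a higher number here means a larger maximal response, a lower number a smaller maximal response.
Compound 2, `CCCn1ccc2cc(-c3ccc(N(C)C)nc3)cc(Cl)c2c1=O`, gives 85% in this assay.

Among these two numbers compound 2 stands highest, and its only neighbour, compound 1, lies far enough below it to count as a real difference rather than scatter. Compound 3, `CCCn1ccc2cc(-c3ccc(OCCc4ccccc4)nc3)cc(Cl)c2c1=O`, has not yet been measured. It differs from compound 2 in one place: phenethyloxy in place of dimethylamino on an aromatic carbon. The dimethylamino group is thus exchanged for a phenethyloxy group, a larger chain that brings a six-membered aromatic ring of carbon only with it.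

Among the compounds with values here, no measured pair here shows what such an exchange does to the largest response in this assay, so the expectation rests on the two values alone and is uncertain. A step downward from the high value of compound 2 is expected, of moderate size, and the estimated shift is a number 25 percentage points lower from compound 2 to compound 3 (beyond the scatter). For compound 3 the expected result in this assay is 60%, within a range of 30% to 95%.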

Compound 3, largest response reached (Emax), in percent of the reference or control that the assay uses: 103%
The estimate for compound 3 lay 43 percentage points below the measured number; measured number above the stated range.
By their numbers in this assay, from the lowest: compound 1; then compound 2; then compound 3.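

This position accepts a much larger group than dimethylamino without losing response: in this assay, the exchange for phenethyloxy gives a number 18 percentage points higher from compound 2 to compound 3 (beyond the scatter) and so carries the series further upward. The new chain, which brings a six-membered aromatic ring of carbon only, sits on the aromatic carbon next to the ring nitrogen, so this place has room for more than a small amino group. The data shown offer no measured explanation for why the response rises.

Going by these compounds, it remains open whether the gain depends on the carbon-only ring, the ether oxygen or the chain length, and a shorter benzyloxy group or a small methoxy group would help separate these parts. A ring-bearing amine such as morpholine at this place is also an open case.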